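Dihydrobenzoxazinone sulfonamides: cyclohexyl versus 4-methylphenyl on the ring nitrogen

The compounds below may be only part of what the source reports. "The series", "measured", "known", "first", "only" and "open" are said of these compounds alone.

Measured so far in a functional assay on HCT-116 cells (Homo sapiens) for antiproliferative activity, read by MTT assay, with a stated time of 72 h; a lower number here means a stronger inhibitor, a higher number a weaker inhibitor:
- compound 1, `COc1ncc(-c2ccc3c(c2)N(c2ccc(C)cc2)C(=O)CO3)cc1NS(=O)(=O)c1ccc(F)cc1`: 22700 nM
- compound 2, `COc1ncc(-c2ccc3c(c2)N(C2CCCCC2)C(=O)CO3)cc1NS(=O)(=O)c1ccc(F)cc1`: > 40000 nM
- compound 3, `O=C1COc2ccc(-c3cccc(NS(=O)(=O)c4ccc(F)cc4)c3)cc2N1C1CCCCC1`: 18300 nM

Compound 2 reaches only a limit of this assay, > 40000 nM, and gives no number. Compound 1 differs from compound 2 by 4-methylphenyl in place of cyclohexyl on an amide-type nitrogen in a ring; the step is an at least 1.7-fold lower number from compound 2 to compound 1 (0.24 log units; that floor lies within the scatter), and its floor follows from the limit of > 40000 nM in this assay, at which 1 of the 3 values shown sits, rather than from a measured number. Compound 3 carries a different core from compound 2; the difference between the two cores is not broken down here. Compound 3 and compound 1 sit within the scatter of each other, so no order between them is claimed.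

Compound 4, `Cc1ccc(N2C(=O)COc3ccc(-c4cccc(NS(=O)(=O)c5ccc(F)cc5)c4)cc32)cc1`, is not yet measured. It differs from compound 3 by 4-methylphenyl in place of cyclohexyl on an amide-type nitrogen in a ring, the same change as that from compound 2 to compound 1, at the same place on the ring nitrogen. Going by the values given here, the only precedent is the step of an at least 1.7-fold lower number from compound 2 to compound 1 (0.24 log units; that floor lies within the scatter), which lies within the scatter. The step from compound 3 to compound 4 is therefore expected to be small and in the same direction, a 1.5-fold lower number from compound 3 to compound 4 (0.18 log units; within the scatter), resting on compound 3 at 18300 nM. Compound 4 is therefore estimated at 12000 nM in this assay, with a plausible range from 5000 nM to 30000 nM.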

Compound 4, half-maximal inhibitory concentration: 35600 nM
Compound 4: middle estimate off by 3.0-fold (0.47 log units), on the low side; measured number outside the range, above it.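

In this assay, the step on the core of compound 3 is a 1.9-fold higher number from compound 3 to compound 4 (0.29 log units; within the scatter), so on this core, taken alone, placing 4-methylphenyl in place of cyclohexyl on the amide-type nitrogen gives no change beyond the scatter. Set beside the earlier step, the change cannot be assumed to carry over in the same direction from one core to the other in this series: the same change on two cores in this assay, an at least 1.7-fold lower number (0.24 log units; that floor lies within the scatter) from compound 2 to compound 1 and a 1.9-fold higher number (0.29 log units; within the scatter) from compound 3 to compound 4, at least 3.4-fold (0.53 log units) apart, beyond the scatter of two such steps Compound 2 stands at > 40000 nM, which is a limit of the assay and not a number, so the size of the earlier step stays unknown, and a single pair on each core does not show which part of the core lies behind the difference: the limit of > 40000 nM in this assay, at which 1 of the 4 values shown sits.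

The compounds shown leave open how other groups on the amide-type nitrogen would behave on these two cores, for instance a longer chain such as n-butyl, a chain ending in an amine, or one ending in a carboxylic acid. They also leave open whether a measured number on the core of compound 1 could be obtained with cyclohexyl replaced by such a group, which would allow a comparison free of the limit.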